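Working notes: 4-acetylphenyl to 4-methylphenyl in compound 3

This account rests on a few compounds, and the source may have more. Where it says the series, first, only, none or still open, it means among the compounds named here.

Of the compounds shown here, three have numbers so far in an ADME assay on HEK293 cells (Homo sapiens) for cytotoxicity, read by MTT assay, with a stated time of 48 h; on this read-out lower numbers stand for stronger inhibition and higher numbers for weaker inhibition. Compound 1 (`C=C1CCC[C@]2(C)CCC(C=O)=CC[C@@]12C`) gives 734000 nM, compound 2 (`C#CC1=CC[C@]2(CC1)C(=C)CC[C@H]2C(C)C`) gives 741000 nM, and compound 3 (`C=C1CCC[C@]2(C)CCC(c3cn(-c4ccc(C(C)=O)cc4)nn3)=CC[C@@]12C`) gives 520000 nM. Compound 3 stands within the scatter of both compound 1 and compound 2, so these numbers do not separate it from either.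

The next compound, compound 4 (`C=C1CCC[C@]2(C)CCC(c3cn(-c4ccc(C)cc4)nn3)=CC[C@@]12C`), has not yet been measured. It carries methyl in place of acetyl on an aromatic carbon of a six-membered aromatic ring of carbon only, para to a large group: methyl in place of acetyl on an aromatic carbon.

For the measured compounds named here, the series offers no measured step between compounds that differ in one place, so the size of this change cannot be read directly. The expectation rests on the values alone: compound 1 at 734000 nM and compound 3 at 520000 nM lie within the scatter of each other while carrying different groups on the shared core. The estimated step of a 1.0-fold lower number from compound 3 to compound 4 (0.02 log units; within the scatter) is expected to stay within the scatter, with no direction favoured in this assay. For compound 4 the expected value is 500000 nM, with an estimated range from 260000 nM to 850000 nM.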

Compound 4, half-maximal inhibitory concentration: 524000 nM
Compound 4: the middle estimate sits 1.0-fold (0.02 log units) below what was measured; measured number inside the range.
By their numbers in this assay, from the lowest: compounds 3, 4, 1 and 2 (each within the scatter of the next).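

In this assay the aromatic carbon para to a large group now has its first direct reading: methyl in place of acetyl gives a 1.0-fold higher number from compound 3 to compound 4 (0.00 log units; within the scatter). The earlier compounds shown here differ from one another in more than one place and could not isolate a single change, whereas this pair shows that exchanging the acetyl, with its carbonyl and hydrogen-bond acceptor, for methyl does not separate the two compounds on this read-out. No measurement at hand bears on why the two compounds read alike.

Going by these compounds, it remains open whether any group at this position can move the number beyond the scatter in this assay, and an amine or a carboxylic acid in place of the methyl would test that. On these data alone, it also remains open whether the exchange of acetyl for methyl would read the same way on a different core, since this single pair is the only one that carries it.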